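The source may report more compounds than this note shows. Statements on the series, on what has been measured and on what is new or still open speak of the compounds shown alone.

For the measured compounds named here, compound 1, with the structure `CCOC(=O)C(=O)Nc1ccccc(C)c1=O`, is one of two compounds measured in a functional assay on the whole organism (strain Sprague-Dawley CD) for inhibition, with Rattus norvegicus as the target, read by paw edema, at a dose of 100 mg/kg by the oral route (on this read-out lower numbers stand for a weaker effect and higher numbers for a stronger effect at the one dose given), where compound 1 gives 34%. Compound 2, with the structure `CCOC(=O)C(=O)Nc1ccccc(Br)c1=O`, shares the same core and differs only in that a bromo group sits where compound 1 carries a methyl group on an aromatic carbon; in this assay compound 2 gives 0%. Going by the values given here, that single change produced the one step known so far, a number 34 percentage points lower from compound 1 to compound 2 (beyond the scatter), so compound 2 stands at the lowest of the two numbers, with compound 1 as its only neighbour and a clearly stronger one.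

Compound 3, with the structure `CCOC(=O)C(=O)Nc1ccccc(O)c1=O`, is not yet measured. It differs from compound 2 by hydroxy in place of bromo on an aromatic carbon. Among the compounds with values here, no measured step involves a hydroxy group, and the only step available, from methyl to bromo, shows that a change at this one position can move the read-out by a large amount in either direction. On that slender basis, the expected step of a number 15 percentage points higher from compound 2 to compound 3 (beyond the scatter) is a modest rise, since compound 2 already sits at zero and cannot go lower. The estimate for compound 3 in this assay is therefore 15%, within a range from 0% to 40%.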

Compound 3, a percentage reported as inhibition, in the whole organism at one dose (the size of the read-out at that dose, not a potency): 0%
Compound 3: middle estimate off by 15 percentage points, on the high side; low and high end bracket the measured number.
By their numbers in this assay, from the lowest: compounds 2 and 3 (each within the scatter of the next); then compound 1.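

In this assay, placing hydroxy where compound 2 carries bromo on this aromatic carbon gives no change at the digits printed from compound 2 to compound 3 (within the scatter) and so leaves the read-out where it was. The other new comparison, a number 34 percentage points lower from compound 1 to compound 3 (beyond the scatter) when hydroxy replaces methyl, shows that the loss seen with bromo is not unique to bromo: of the three groups seen at this position, only the methyl of compound 1 goes with a measurable effect at this dose, even though hydroxy and bromo differ in their counts of hydrogen-bond donors and acceptors. No measurement at hand explains why the methyl compound alone keeps an effect.

The compounds shown leave open whether methyl is a narrow exception or whether a larger carbon group, such as ethyl or a longer chain, would keep or raise the effect at this position. They also leave open how an amine or a methoxy group would read here, and whether compound 2 and compound 3 would show any effect at a higher dose.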